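A hydroxyhexyl chain in place of a phenyl ring

The source may hold more compounds than are shown below. What is called first, only, known or untested is meant among the compounds shown, and "the series" means these compounds.

Of the compounds shown here, three have so far been measured in a functional assay on HEK293 cells for agonist activity at prostaglandin E2 receptor EP2 subtype (Rattus norvegicus), read by cAMP accumulation; on this read-out lower numbers stand for an effect already at smaller amounts and higher numbers for an effect only at larger amounts of compound. Compound 1 `CCCCc1ccc(CN(c2ccccc2CCCC(=O)O)S(C)(=O)=O)cc1` gives 103 nM in this assay. Compound 2 `CCCCC(O)c1ccc(CN(CCCCCCC(=O)O)S(C)(=O)=O)cc1` gives 423 nM, and compound 3 `CS(=O)(=O)N(CCCCCCC(=O)O)Cc1ccc(-c2ccccc2)cc1` gives 457 nM. Compound 3 carries the highest of the three numbers; its nearest neighbour is compound 2, within the scatter, while compound 1 lies furthest off, beyond it. Among the measured compounds shown here, the only single-point change with a known step is a 1.1-fold higher number from compound 2 to compound 3 (0.03 log units; within the scatter). Compound 4 `CCCCCC(O)c1ccc(CN(CCCCCCC(=O)O)S(C)(=O)=O)cc1` differs from compound 3 by 1-hydroxyhexyl in place of phenyl on an aromatic carbon. This is close to that step run backwards, with 1-hydroxyhexyl instead of 1-hydroxypentyl, so no step beyond the scatter is expected in this assay. Compound 4 is therefore estimated at 420 nM, between 200 nM and 900 nM, a step of a 1.1-fold lower number from compound 3 to compound 4 (0.04 log units; within the scatter).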

Compound 4, half-maximal effective concentration: 44 nM
The estimate for compound 4 lay 9.5-fold (0.98 log units) above the measured number; the measured number lies below the stated range.
By their numbers in this assay, from the lowest: compound 4; then compound 1; then compounds 2 and 3 (each within the scatter of the next).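

In this assay the aromatic carbon para to a large group proves sensitive to the length of the hydroxylated chain: 1-hydroxyhexyl in place of phenyl brings a 10-fold lower number from compound 3 to compound 4 (1.02 log units; beyond the scatter) even though 1-hydroxypentyl and phenyl stand within the scatter of each other. Nearly the same drop appears as a 9.6-fold lower number from compound 2 to compound 4 (0.98 log units; beyond the scatter) with only one added methyl on the saturated chain. Nothing available explains this sharp dependence on chain length. As far as these compounds go, whether a longer chain, or an amine or carbonyl in place of the hydroxyl, keeps the low number remains open. So does whether 1-hydroxyhexyl acts likewise on the core of compound 1.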